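The compounds below may be only part of what the source reports. "The series", "measured", "known", "first", "only" and "open" are said of these compounds alone.

Of the compounds shown here, three that share one core have been measured in a functional assay on SMMC-7721 cells (Homo sapiens) for antiproliferative activity, read by MTT assay, with a stated time of 72 h; a lower number here means a stronger inhibitor, a higher number a weaker inhibitor. Compound 1 `Cc1nn(C)c(Oc2ccc(OC(F)(F)F)cc2)c1/C=N\OCc1c(Cl)c(-c2ccc(F)cc2)nn1C` gives 5210 nM, compound 2 `Cc1nn(C)c(Oc2ccc(F)cc2)c1/C=N\OCc1c(Cl)c(-c2ccc(Cl)cc2)nn1C` gives 3230 nM, and compound 3 `COc1ccc(Oc2c(/C=N\OCc3c(Cl)c(-c4ccc(Cl)cc4)nn3C)c(C)nn2C)cc1` gives 760 nM, the lowest of the three numbers. Among the compounds with values here, the only single-point comparison available is a 4.3-fold lower number from compound 2 to compound 3 (0.63 log units; beyond the scatter), which came from methoxy in place of fluoro on an aromatic carbon. Compound 4 `Cc1nn(C)c(Oc2ccc(OC(F)(F)F)cc2)c1/C=N\OCc1c(Cl)c(-c2ccc(Cl)cc2)nn1C` differs from compound 3 by trifluoromethyl in place of methyl on an oxygen on an aromatic ring. Within the data shown here, no measured step matches this change directly. Compound 1, which also carries a 4-(trifluoromethoxy)phenoxy group, gives a number well above compound 3, so compound 4 is expected to lose ground in this assay. Compound 4 is therefore estimated at about 3000 nM, within 1000 nM to 9000 nM, an expected step of a 3.9-fold higher number from compound 3 to compound 4 (0.60 log units; beyond the scatter).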

Compound 4, half-maximal inhibitory concentration: 8670 nM
Compound 4: middle estimate off by 2.9-fold (0.46 log units), on the low side, and the stated range covers the measured number.
By their numbers in this assay, from the lowest: compound 3; then compounds 2, 1 and 4 (each within the scatter of the next, the first and the last beyond it).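

Trifluoromethyl in place of methyl on the oxygen gives an 11-fold higher number from compound 3 to compound 4 (1.06 log units; beyond the scatter) here, the first direct reading of this change, and a large one. Trifluoromethoxy in place of fluoro on the aromatic carbon gives a 2.7-fold higher number from compound 2 to compound 4 (0.43 log units; beyond the scatter) as well, so among compounds 3, 2 and 4 the methoxy compound has the lowest number and the trifluoromethoxy compound the highest. Chloro in place of fluoro on an aromatic carbon gives a 1.7-fold higher number from compound 1 to compound 4 (0.22 log units; within the scatter) and so does not separate the two compounds. Nothing available explains the size of the methoxy to trifluoromethoxy step. From the compounds shown here alone, how an amine or a longer alkoxy chain would compare with methoxy on this aromatic carbon remains open.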